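A few compounds are considered here, and "the series" means these few. Any claim that something is new, unique, unknown or untested is made for them only; others in the source may bear on it.

Series notes. In an assay on BTI-TN-5B1-4 cells for inhibition of Amine oxidase [flavin-containing] A (Homo sapiens), read by fluorescence and Amplex Red, using microsomes, with a stated time of 15 min (a lower number here means a stronger inhibitor, a higher number a weaker inhibitor), compound 1 `C#CCN1CCC(COC(=O)Nc2ccc(C(C)C)cc2)CC1` gives > 100000 nM, which is a limit of the assay and not a number. Compound 2 `CC(C)c1ccc(NC(=O)OCC2CCN(Cc3ccccc3)CC2)cc1` gives > 100000 nM in this assay, again only a limit. The change between these two is phenyl in place of ethynyl on a saturated chain carbon bound to an amine nitrogen in a ring, and the resulting step is a step that the two limits leave unreadable from compound 1 to compound 2, since the limit of > 100000 nM in this assay, at which 3 of the 3 values shown sit, applies to every value shown so far. Compound 3 `C#CCN1CCCC(COC(=O)N(C)CC)C1` gives > 100000 nM in this assay, also a limit. The difference between the core of compound 3 and the core of compound 1 is not broken down here. Compound 4 `CCN(C)C(=O)OCC1CCCN(Cc2ccccc2)C1` has not yet been measured in this assay; it differs from compound 3 by phenyl in place of ethynyl on a saturated chain carbon bound to an amine nitrogen in a ring, the same change as that between compound 1 and compound 2, at the same place. Because the same change gave a step that the two limits leave unreadable from compound 1 to compound 2, the expected step in this assay is a step that the limit leaves unreadable from compound 3 to compound 4. Compound 4 is therefore estimated at 200000 nM, somewhere between 50000 nM and 1000000 nM, and most probably reported again only as a limit.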

Compound 4, half-maximal inhibitory concentration: > 100000 nM
Compound 4 ended at the assay's limit; the forecaster's own chance of this, stated with the estimate: 85%; the middle value lies beyond the limit too.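

No step can be read from compound 3 to compound 4 in this assay, since both values are limits of the assay and not numbers: the limit of > 100000 nM in this assay, at which 4 of the 4 values shown sit.

The compounds shown leave open whether phenyl in place of ethynyl changes inhibition at all.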